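The source may report more compounds than this note shows. Statements on the series, on what has been measured and on what is new or still open speak of the compounds shown alone.

Binding values in an in vitro assay on 293-EBNA cells for binding affinity to corticotropin-releasing factor receptor 1 (Homo sapiens) (a higher number here means a weaker inhibitor, a lower number a stronger inhibitor), for the three measured compounds:
Compound 1 `Cc1nc(N2CCCCC2)c2nnn(-c3ccc(C(C)C)cc3Br)c2n1`: 46 nM
Compound 2 `Cc1nc(N2CCCC2)c2nnn(-c3ccc(C(C)C)cc3Br)c2n1`: 194 nM
Compound 3 `COCC(C)(C)Nc1nc(C)nc2c1nnn2-c1ccc(C(C)C)cc1Br`: 195 nM

Compound 3 gives the highest number of the three, but its gap to compound 2 lies within the scatter; only compound 1 is clearly lower, by a 4.2-fold higher number from compound 1 to compound 3 (0.63 log units; beyond the scatter). Compound 4 `CCCCC(CC)Nc1nc(C)nc2c1nnn2-c1ccc(C(C)C)cc1Br` differs from compound 3 by 1-ethylpentyl in place of 1-(methoxymethyl)-1-methylethyl on a nitrogen on an aromatic ring. The measured steps, a 4.2-fold higher number from compound 1 to compound 2 (0.63 log units; beyond the scatter) and a 1.0-fold higher number from compound 2 to compound 3 (0.00 log units; within the scatter), swap a ring for a ring or a ring for a chain; none exchanges one open chain for another, so none bears directly on this change. The expectation for compound 4 is therefore a step of a 2.8-fold lower number from compound 3 to compound 4 (0.44 log units; beyond the scatter), with wide uncertainty. Compound 4 is estimated at 70 nM, within 15 nM to 300 nM.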

Compound 4, inhibition constant: 3.1 nM
The estimate for compound 4 lay 23-fold (1.35 log units) above the measured number; the whole stated range lies above it.
By their numbers in this assay, from the lowest: compound 4; then compound 1; then compounds 2 and 3 (each within the scatter of the next).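

On a nitrogen on an aromatic ring, the choice of open chain can matter greatly: in this assay, 1-ethylpentyl in place of 1-(methoxymethyl)-1-methylethyl gives a large drop (a 63-fold lower number from compound 3 to compound 4 (1.80 log units; beyond the scatter)). The same (1-ethylpentyl)amino group also gives lower numbers than both ring amines, pyrrolidin-1-yl (a 63-fold lower number from compound 2 to compound 4 (1.80 log units; beyond the scatter)) and piperidin-1-yl (a 15-fold lower number from compound 1 to compound 4 (1.17 log units; beyond the scatter)), making compound 4 the strongest inhibitor shown. No measurement available here explains this gain.

The two chains differ in both oxygen content and shape, so neither difference can be singled out. From the compounds shown here alone, how a 1-(methoxymethyl)pentyl chain or a shorter 1-ethylpropyl chain would compare remains open.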